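Notes on the side-chain change from compound 2

A few compounds are considered here, and "the series" means these few. Any claim that something is new, unique, unknown or untested is made for them only; others in the source may bear on it.

- compound 1 `COc1ccc(-c2c(C)nc3c(NCc4ccc(C(N)=O)cc4)cc(C)cn23)cc1OC` gives 6.6
- compound 2 `COc1ccc(-c2c(C)nn3c(NCc4ccc(C(N)=O)cc4)nc(C)cc23)cc1OC` gives 3.8

In a physicochemical assay for acid dissociation, compound 2 stands lowest of the two, with its value beyond the scatter from compound 1 on the lower side. Compound 3 `COc1ccc(-c2c(C)nn3c(NCC4CCOCC4)nc(C)cc23)cc1OC` has oxan-4-yl in place of 4-carbamoylphenyl on a saturated chain carbon bound to a nitrogen on an aromatic ring. Within the data shown here, no measured step covers this change, so the estimate is tentative. The expected step of a number 0.30 log units higher from compound 2 to compound 3 (within the scatter) in this assay is small and upward, near the edge of the scatter. The value estimated for compound 3 is 4.1 with an expected range from 3.6 to 4.7.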

Compound 3, acid dissociation constant: 4.4
Compound 3: middle estimate off by 0.30 log units, on the low side; the measured number falls inside the stated range.
By their numbers in this assay, from the lowest: compound 2; then compound 3; then compound 1.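

At this place, on a saturated chain carbon bound to a nitrogen on an aromatic ring, the read-out in this assay responds to the side chain: oxan-4-yl in place of 4-carbamoylphenyl gives a number 0.60 log units higher from compound 2 to compound 3 (beyond the scatter) on an unchanged core. Compound 1 and compound 2 both carry 4-carbamoylphenyl, so they gave no reading of this place. Nothing measured here accounts for the step.

From the compounds shown here alone, whether the step follows the loss of 4-carbamoylphenyl or the entry of oxan-4-yl remains open with a single pair. Also open, going by these compounds, is what piperidin-4-yl, with its ring amine, or a plain phenyl would give at this place, and whether the same change holds on the core of compound 1.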